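This account rests on a few compounds, and the source may have more. Where it says the series, first, only, none or still open, it means among the compounds named here.

Compound 2 `CC(=O)OCC[C@@H](C)CC[C@@H]1[C@@]2(C)CCCC(C)(C)[C@@H]2CC[C@@]1(C)O` stands level with compound 1 `C[C@H](CCO)CC[C@@H]1[C@@]2(C)CCCC(C)(C)[C@@H]2CC[C@@]1(C)O` on the numbers in hand: in a functional assay on RAW264.7 cells (Mus musculus) for inhibition, read by ELISA, with stated times of 30 min and 24 h (on this read-out higher numbers stand for weaker inhibition and lower numbers for stronger inhibition), compound 1 gives 25000 nM, and compound 2 gives 25000 nM. For the measured compounds named here, the single measured step, no change at the digits printed from compound 1 to compound 2 (within the scatter), brought acetyl in place of hydrogen on an oxygen on a saturated carbon and left the read-out where it was. Compound 3 `C[C@@H](CC[C@@H]1[C@@]2(C)CCCC(C)(C)[C@@H]2CC[C@@]1(C)O)CC(=O)O` differs from compound 2 by carboxy in place of acetoxymethyl on a saturated chain carbon, four bonds along the chain from a saturated ring carbon. Going by the values given here, no measured step involves a carboxy group, so the only step that bears on this one is no change at the digits printed from compound 1 to compound 2 (within the scatter), which was no change within the scatter. On that basis no movement beyond the scatter is expected for the present change either, and the step assumed is no change at the digits printed from compound 2 to compound 3 (within the scatter). Compound 3 is accordingly expected to give about 25000 nM in this assay, with a range of 10000 nM to 60000 nM.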

Compound 3, half-maximal inhibitory concentration: > 50000 nM
Compound 3 ended at the assay's limit (the forecaster's own chance of this, stated with the estimate: 40%); middle value at least 2.0-fold (0.30 log units) from the limit.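

In this assay compound 3 gives > 50000 nM, which is a limit of the assay and not a number. At this position, on a saturated chain carbon, four bonds along the chain from a saturated ring carbon, carboxy in place of acetoxymethyl gives an at least 2.0-fold higher number from compound 2 to compound 3 (0.30 log units; that floor lies within the scatter), and carboxy in place of hydroxymethyl gives an at least 2.0-fold higher number from compound 1 to compound 3 (0.30 log units; that floor lies within the scatter). Compound 3 alone among the three reaches the limit, yet both floors lie within the scatter, so no loss beyond the scatter is established and the true size of the steps stays unknown: the limit of > 50000 nM in this assay, at which 1 of the 3 values shown sits.

Open, as far as these compounds go, is whether an amine or a methyl ester at this chain end would stay level with compound 1 or also reach the limit. Also open, from the compounds shown here alone, is whether a carboxylic acid on a longer chain would read differently from compound 3.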